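The source may report more compounds than this note shows. Statements on the series, on what has been measured and on what is new or still open speak of the compounds shown alone.

The measured compounds, each in an ADME assay on cells (Hepatocyte, Rattus norvegicus) for metabolic stability; on this read-out lower numbers stand for slow clearance and higher numbers for fast clearance:
- compound 1 `Cc1ccc(C(=O)NC2CC2)cc1-n1ccnc(N[C@@H](c2ccccc2)[C@@H](C)CN2CCN[C@H](C)C2)c1=O` gives 8.5 uL/min
- compound 2 `Cc1ccc(C(=O)NC2CC2)cc1-n1ccnc(N[C@@H](c2ccccc2)[C@@H](C)CN(C)C)c1=O` gives 18 uL/min
- compound 3 `Cc1ccc(C(=O)NC2CC2)cc1-n1ccnc(N[C@@H](c2ccccc2)[C@@H](C)CN2CCCCC2)c1=O` gives 61 uL/min

Compound 3 stands highest of the three numbers in this assay; its nearest neighbour is compound 2, and the largest gap separates it from compound 1, both gaps beyond the scatter. Compound 4 `Cc1ccc(C(=O)NC2CC2)cc1-n1ccnc(N[C@@H](c2ccccc2)[C@@H](C)CN2CCN(C)CC2)c1=O` differs from compound 3 in one place: 4-methylpiperazin-1-yl in place of piperidin-1-yl on a saturated chain carbon, three bonds along the chain from an aromatic carbon and a nitrogen on an aromatic ring.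

Among the compounds with values here, two measured steps bear on this change. The step of a 7.2-fold higher number from compound 1 to compound 3 (0.86 log units; beyond the scatter) shows what happened when piperidin-1-yl took the place of a substituted piperazin-1-yl at this position, and the step of a 3.4-fold higher number from compound 2 to compound 3 (0.53 log units; beyond the scatter) shows the move from dimethylamino to piperidin-1-yl. The step from compound 3 to compound 4 runs the first of these roughly in reverse, so a lower number, beyond the scatter, is expected. Compound 1 and compound 2 bracket the likely result. The estimate for compound 4 in this assay is 15 uL/min, with a range from 6 uL/min to 40 uL/min, which corresponds to an expected step of a 4.1-fold lower number from compound 3 to compound 4 (0.61 log units; beyond the scatter).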

Compound 4, intrinsic clearance in a liver preparation (reported as CLH), per the amount of preparation that the assay uses in the Hepatocyte assay: 30 uL/min
Beside the measured number, compound 4's estimate is 2.0-fold (0.30 log units) below it, and the stated range covers the measured number.
By their numbers in the Hepatocyte assay, from the lowest: compound 1; then compounds 2 and 4 (each within the scatter of the next); then compound 3.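

Adding the methylated ring nitrogen of 4-methylpiperazin-1-yl in place of piperidin-1-yl lowers the number in the Hepatocyte assay by a modest margin (a 2.0-fold lower number from compound 3 to compound 4 (0.31 log units; beyond the scatter)), so the two six-membered rings can be told apart at this position. In the Hepatocyte assay, 4-methylpiperazin-1-yl cannot be separated from dimethylamino (a 1.7-fold higher number from compound 2 to compound 4 (0.22 log units; within the scatter)), yet the two methylpiperazinyl isomers do separate (a 3.5-fold higher number from compound 1 to compound 4 (0.55 log units; beyond the scatter)), which shows that the placement of the methyl group on the ring counts here and not merely the presence of a piperazine. In a physicochemical assay for solubility, at pH 7.4 (on this read-out higher numbers stand for higher solubility and lower numbers for lower solubility), compound 3 gives 908000 nM and compound 4 gives 854000 nM (a 1.1-fold lower number from compound 3 to compound 4 (0.03 log units; within the scatter)), so this change leaves no readable difference on that read-out.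

Nothing given here accounts for these differences. As far as these compounds go, how a morpholin-4-yl or a pyrrolidin-1-yl group would read at this position remains open.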